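From Compound 2 to Compound 3: An Aryl Swap

The source may report more compounds than this note shows. Statements on the series, on what has been measured and on what is new or still open speak of the compounds shown alone.

Compound 1, `CN(C)CCNc1nc([C@@H]2CNC[C@H]2c2ccc(F)cc2)nc2ccc(-c3cn[nH]c3)cc12`: 371 nM
Compound 2, `O=c1[nH]c([C@@H]2CN(Cc3ccccc3)C[C@H]2c2cccc(F)c2)nc2ccc(-c3cn[nH]c3)cc12`: 225 nM

Of the compounds shown here, two have so far been measured in an in vitro assay on Sf9 cells for inhibition of Rho-associated protein kinase 2 (Homo sapiens), read by TR-FRET, with a stated time of 25 min; on this read-out higher numbers stand for weaker inhibition and lower numbers for stronger inhibition. Compound 1 `CN(C)CCNc1nc([C@@H]2CNC[C@H]2c2ccc(F)cc2)nc2ccc(-c3cn[nH]c3)cc12` gives 371 nM in this assay, and compound 2 `O=c1[nH]c([C@@H]2CN(Cc3ccccc3)C[C@H]2c2cccc(F)c2)nc2ccc(-c3cn[nH]c3)cc12` gives 225 nM there. Compound 2 has the lower of the two numbers, but its nearest neighbour, compound 1, lies within the usual scatter of it, so the two cannot be ordered. Among the compounds with values here, no two measured compounds differ in a single place, and therefore no measured step is available to guide a forecast.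

Compound 3 `COc1ccc([C@@H]2CN(Cc3ccccc3)C[C@H]2c2nc3ccc(-c4cn[nH]c4)cc3c(=O)[nH]2)cc1` has not yet been measured in this assay. Compared with compound 2 it differs as follows: 4-methoxyphenyl in place of 3-fluorophenyl on a saturated ring carbon. Within the data shown here, no measured step bears on this particular change, so the step of a 1.4-fold higher number from compound 2 to compound 3 (0.15 log units; within the scatter) is expected to be small, most likely no further than the scatter, with a slight lean toward a higher number. Compound 3 is accordingly expected to give about 320 nM in this assay, within an estimated range from 120 nM to 850 nM.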

Compound 3, half-maximal inhibitory concentration: 88 nM
Compound 3: the middle estimate sits 3.6-fold (0.56 log units) above what was measured, and the stated range ends above it.
By their numbers in this assay, from the lowest: compound 3; then compounds 2 and 1 (each within the scatter of the next).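

In this assay, within the data shown here, the exchange of 3-fluorophenyl for 4-methoxyphenyl on the saturated ring carbon gives a 2.6-fold lower number from compound 2 to compound 3 (0.41 log units; beyond the scatter) and so provides the first measured single-place step in this set. The earlier compounds could not show this, since no two of them differed in one place alone; this carbon, next to the ring atom that bears a large group, is now shown to be a place where a change of aryl group can move the number beyond the scatter. The exchange alters both the substituent and where it stands on the phenyl ring, so the two are not separated here, and no supporting measurement is available to explain the lower number.

The compounds shown leave open whether the methoxy group or its location carries the step, a question that 3-methoxyphenyl or plain phenyl at this carbon would address. They also leave open how far the step extends to other groups at this carbon, such as 4-ethoxyphenyl, 4-hydroxyphenyl or 4-aminophenyl.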